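From compound 3 to compound 4: ring and link change

The source may hold more compounds than are shown below. What is called first, only, known or untested is meant among the compounds shown, and "the series" means these compounds.

Measured in a functional assay on RS4-11 cells (Homo sapiens) for inhibition, read by CCK-8 assay, with a stated time of 72 h; a higher number here means a weaker inhibitor, a lower number a stronger inhibitor:
- compound 1 `CC1(C)CCC(CN2CCN(c3ccc(C(=O)NS(=O)(=O)c4ccc(NCC5CCOCC5)c([N+](=O)[O-])c4)c(Oc4cnc5[nH]ccc5c4)c3)CC2)=C(c2ccc(C(F)(F)F)cc2)C1`: 6.2 nM
- compound 2 `CN1CCC(CNc2ccc(S(=O)(=O)NC(=O)c3ccc(N4CCN(CC5=C(c6ccc(C(F)(F)F)cc6)CC(C)(C)CC5)CC4)cc3Oc3cnc4[nH]ccc4c3)cc2[N+](=O)[O-])C1`: 8.3 nM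
- compound 3 `CC1(C)CCC(CN2CCN(c3ccc(C(=O)NS(=O)(=O)c4ccc(NCC5CCOC5)c([N+](=O)[O-])c4)c(Oc4cnc5[nH]ccc5c4)c3)CC2)=C(c2ccc(C(F)(F)F)cc2)C1`: 24.2 nM

Compound 3 has the highest number of the three, and so is the weakest inhibitor here: a 2.9-fold higher number from compound 2 to compound 3 (0.46 log units; beyond the scatter) and a 3.9-fold higher number from compound 1 to compound 3 (0.59 log units; beyond the scatter). The other two do not separate: a 1.3-fold higher number from compound 1 to compound 2 (0.13 log units; within the scatter).

Next is compound 4 `CC1(C)CCC(CN2CCN(c3ccc(C(=O)NS(=O)(=O)c4ccc(OCC5CCOCC5)c([N+](=O)[O-])c4)c(Oc4cnc5[nH]ccc5c4)c3)CC2)=C(c2ccc(C(F)(F)F)cc2)C1`. The change is (oxan-4-yl)methoxy in place of ((oxolan-3-yl)methyl)amino on an aromatic carbon, ortho to a nitro group.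

The change has two parts. The swap of oxolan-3-yl for oxan-4-yl has a measured counterpart on the amino chain, read in reverse: a 3.9-fold higher number from compound 1 to compound 3 (0.59 log units; beyond the scatter). Among the compounds with values here, the swap of amino for methoxy has no measured counterpart, which leaves the range wide and suggests giving back part of that gain.

A small step to a lower number is expected: a 1.7-fold lower number from compound 3 to compound 4 (0.24 log units; within the scatter). For compound 4 the estimated value is 14 nM, with an expected range of 4 nM to 50 nM.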

Compound 4, half-maximal inhibitory concentration: 5.9 nM
Compound 4: middle estimate off by 2.4-fold (0.38 log units), on the high side; measured number inside the range.
By their numbers in this assay, from the lowest: compounds 4, 1 and 2 (each within the scatter of the next); then compound 3.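

In this assay, the step of a 1.1-fold lower number from compound 1 to compound 4 (0.02 log units; within the scatter) holds the oxan-4-yl ring fixed and changes only the link, and it lies within the scatter, so at this position on the aromatic carbon the methoxy link with no hydrogen-bond donor reads the same as the amino link. The step of a 4.1-fold lower number from compound 3 to compound 4 (0.61 log units; beyond the scatter) is beyond the scatter and is of similar size to the reverse of the ring step a 3.9-fold higher number from compound 1 to compound 3 (0.59 log units; beyond the scatter) on the amino chain, so among these compounds the difference from compound 3 goes with the ring, while a 1.4-fold lower number from compound 2 to compound 4 (0.15 log units; within the scatter) shows no separation from the basic-free comparison. No measurement on hand explains these steps.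

Open, as far as these compounds go, is whether the link swap also reads as neutral with the oxolan-3-yl ring. A sulfur link or a longer chain between the aromatic carbon and the oxan-4-yl ring also remains to be read at this position.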